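The source may hold more compounds than are shown below. What is called first, only, known or untested is meant among the compounds shown, and "the series" means these compounds.

In an assay on HEK293 cells for agonist activity at transient receptor potential cation channel subfamily M member 8 (Homo sapiens), read by fluorescence and calcium flux, with a stated time of 15 min (a lower number here means that less compound is needed, a higher number that more compound is needed for the effect), three compounds share one core and differ only in the group on the amide-type nitrogen. Compound 1 `CCN(Cc1cccs1)C(=O)COc1ccc(C)cc1` gives 8 nM, compound 2 `Cc1ccc(OCC(=O)N(Cc2cccs2)CC(C)C)cc1` gives 900 nM, and compound 3 `Cc1ccc(OCC(=O)N(Cc2cccs2)c2ccccn2)cc1` gives 200 nM. Compound 3 thus stands second highest of the three numbers: the step of a 4.5-fold lower number from compound 2 to compound 3 (0.65 log units; beyond the scatter) separates it from its nearest neighbour, while the step of a 25-fold higher number from compound 1 to compound 3 (1.40 log units; beyond the scatter) separates it from compound 1, the furthest.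

Compound 4 `Cc1ccc(OCC(=O)N(Cc2cccs2)C(C)(C)C)cc1` differs from compound 3 in one place: tert-butyl in place of pyridin-2-yl on an amide-type nitrogen. Among the compounds with values here, two measured steps bear on this. Enlarging the saturated group on this nitrogen from ethyl to isobutyl gave a 110-fold higher number from compound 1 to compound 2 (2.05 log units; beyond the scatter), a large rise. Swapping isobutyl for pyridin-2-yl gave a 4.5-fold lower number from compound 2 to compound 3 (0.65 log units; beyond the scatter), a modest fall, so going back from the pyridin-2-yl of compound 3 to a saturated group with no ring is expected to reverse that fall. Tert-butyl is a four-carbon group without a ring, closer in kind to the isobutyl of compound 2 than to the ethyl of compound 1, so the number for compound 4 is expected to land near that of compound 2 or somewhat above it. Compound 4 is therefore estimated at 1500 nM, plausibly between 300 nM and 8000 nM, which would mean an expected step of a 7.5-fold higher number from compound 3 to compound 4 (0.88 log units; beyond the scatter).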

Compound 4, half-maximal effective concentration: 11000 nM
Estimate against measurement, compound 4: 7.3-fold (0.87 log units) below; measured number above the stated range.
By their numbers in this assay, from the lowest: compound 1; then compound 3; then compound 2; then compound 4.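

Tert-butyl in place of ethyl on the amide-type nitrogen gives a 1400-fold higher number from compound 1 to compound 4 (3.14 log units; beyond the scatter) and so opens the widest gap in the set, showing how strongly the number depends on the group at this position. Tert-butyl in place of isobutyl still gives a 12-fold higher number from compound 2 to compound 4 (1.09 log units; beyond the scatter) even though neither group has a ring, so the absence of a ring does not by itself set the number, and saturated groups at this position can differ widely from one another. Tert-butyl in place of pyridin-2-yl gives a 55-fold higher number from compound 3 to compound 4 (1.74 log units; beyond the scatter), which places the ring-bearing group far lower than tert-butyl, but no simple rule that a ring lowers the number holds, as compound 1 goes against it: its ethyl group has no ring, yet it has the lowest number of the four.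

As far as these compounds go, whether methyl, a straight propyl chain or a cyclopropyl ring on this nitrogen would match or improve on the ethyl of compound 1 remains open. No measurement shown here explains why these groups differ so much.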